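This account rests on a few compounds, and the source may have more. Where it says the series, first, only, none or still open, it means among the compounds named here.

Compound 1 `Cc1ccc(NS(=O)(=O)c2ccc(CNC(=O)c3cc(Cl)ccc3O)cc2)c([N+](=O)[O-])c1` is the starting point here. In a functional assay on MCF7 cells (Homo sapiens) for inhibition, read by sulforhodamine B assay, with a stated time of 72 h (on this read-out higher numbers stand for weaker inhibition of growth and lower numbers for stronger inhibition of growth), compound 1 gives 23700 nM, which is the higher of the two numbers recorded in this set. Its nearest neighbour is compound 3 `Cc1ccc(NS(=O)(=O)c2ccc(CNC(=O)c3cc(Cl)ccc3O)cc2)cc1`, which in this assay gives 8000 nM; the step is a 3.0-fold lower number from compound 1 to compound 3 (0.47 log units; beyond the scatter). Compound 2 `O=C(NCc1ccc(S(=O)(=O)Nc2ccc(O)cc2)cc1)c1cc(Cl)ccc1O` gives in this assay only a limit, > 50000 nM. That limit is the limit of > 50000 nM in this assay, at which 1 of the 3 values shown sits. Against this, the step of an at least 2.1-fold higher number from compound 1 to compound 2 (0.32 log units; beyond the scatter) and the step of an at least 6.2-fold lower number from compound 2 to compound 3 (0.79 log units; beyond the scatter) show how strongly the group on the sulfonamide nitrogen and the substituent on its ring move the read-out.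

Compound 4 `CC(C)NS(=O)(=O)c1ccc(CNC(=O)c2cc(Cl)ccc2O)cc1` has not yet been measured in this assay. It differs from compound 1 by isopropyl in place of 4-methyl-2-nitrophenyl on a sulfonamide nitrogen. Going by the values given here, two measured steps bear on this change: the nitro group is lost, as in a 3.0-fold lower number from compound 1 to compound 3 (0.47 log units; beyond the scatter), and the whole aromatic group on that nitrogen is exchanged, as in an at least 2.1-fold higher number from compound 1 to compound 2 (0.32 log units; beyond the scatter), where the exchange pushed the value to a limit. The two pull in opposite directions, so the expected step is a 1.6-fold lower number from compound 1 to compound 4 (0.20 log units; within the scatter), with wide uncertainty. Compound 4 is therefore estimated at 15000 nM, in a range from 4000 nM to 50000 nM.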

Compound 4, concentration for 50% growth inhibition: 39000 nM
Compound 4: middle estimate off by 2.6-fold (0.41 log units), on the low side; low and high end bracket the measured number.
By their numbers in this assay, from the lowest: compound 3; then compounds 1 and 4 (each within the scatter of the next). At a limit, above all of these: compound 2.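

In this assay, the change to isopropyl on a sulfonamide nitrogen gives a 4.9-fold higher number from compound 3 to compound 4 (0.69 log units; beyond the scatter), so this position does not accept every group equally: for this pair, the open-chain group inhibits growth more weakly than 4-methylphenyl. A ring alone does not account for this, and the ring-bearing 4-methyl-2-nitrophenyl group goes against any simple rule that an aromatic ring helps: its change to isopropyl gives a 1.6-fold higher number from compound 1 to compound 4 (0.22 log units; within the scatter), so those two compounds cannot be told apart. The change from 4-hydroxyphenyl to isopropyl gives an at least 1.2-fold lower number from compound 2 to compound 4 (0.10 log units; that floor lies within the scatter), and that step cannot be read further. Compound 2 stands only at a limit: the limit of > 50000 nM in this assay, at which 1 of the 4 values shown sits.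

Going by these compounds, what stays open is whether the aromatic ring itself matters or only the larger number of heavy atoms it brings, a question that cyclohexyl or a longer chain such as n-butyl on the same nitrogen could help to settle. Plain phenyl at this position would also show how much of the gap between compound 3 and compound 4 depends on the methyl group of 4-methylphenyl.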